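The compounds below may be only part of what the source reports. "The series", "measured", "known", "first", "only" and "open" are said of these compounds alone.

Measured compounds:
compound 1 `NC(=S)Nc1ccccc1CO` — < 10%
compound 2 `Cc1ccc(/C=N/NC(N)=S)cc1` — 64%

Going by the values given here, in a functional assay on B16 cells (Mus musculus) for inhibition, tested at 10 uM (on this read-out higher numbers stand for more inhibition at the one concentration tested (going by the name of the read-out) and lower numbers for less inhibition), compound 2 gives 64%, the only number among the measured compounds. For compound 1 the value < 10% is a limit of this assay, not a number, as noted in the limit of < 10% in this assay, at which 1 of the 2 values shown sits. Compound 3 `CCc1ccc(/C=N/NC(N)=S)cc1` has not been measured in this assay. It differs from compound 2 by methyl in place of hydrogen on a saturated chain carbon bound to an aromatic carbon. Among the compounds with values here, with no measured step available, the change from compound 2 to compound 3 is expected to stay within the scatter, in either direction, with the step of a number 2 percentage points lower from compound 2 to compound 3 (within the scatter) in this assay. Compound 3 is expected to give about 62%, between 45% and 78%.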

Compound 3, a percentage reported as inhibition, at one concentration (the size of the read-out at that concentration, not a potency): 100%
For compound 3 the middle estimate is 38 percentage points below the measured one; the measured number lies above the stated range.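

Methyl in place of hydrogen on a saturated chain carbon bound to an aromatic carbon gives a number 36 percentage points higher from compound 2 to compound 3 (beyond the scatter) in this assay and so shows that this position responds strongly to a small change. Going by these compounds alone, this is the first measured step, and it shows that adding a single carbon, turning methyl into ethyl, can matter here. Nothing among the data shown explains the size of this step. Still open, going by these compounds, is whether a longer chain such as propyl would go on in the same direction. An amine or a carboxylic acid at this place also remains untested among the compounds shown.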